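Adding a Second Chloro to the Core of Compound 1

This account rests on a few compounds, and the source may have more. Where it says the series, first, only, none or still open, it means among the compounds named here.

Compound 1 `ClCc1ccc(Cn2cnc3c(Cl)ncnc32)cc1` stands at the top of the two numbers measured: in a functional assay on EKVX cells (Homo sapiens) for cytotoxicity, read by sulforhodamine B assay, with a stated time of 48 h (on this read-out lower numbers stand for stronger inhibition of growth and higher numbers for weaker inhibition of growth), compound 1 gives 6920 nM. Compound 2 `ClCc1ccccc1Cn1cnc2c(Cl)nc(Cl)nc21`, which differs from it in two places, gives a lower number of 3230 nM in this assay. Compound 3 `ClCc1ccc(Cn2cnc3c(Cl)nc(Cl)nc32)cc1` is compound 1 with one change, (chloro in place of hydrogen on an aromatic carbon). Among the compounds with values here, no single step of this kind has been measured, so the expectation rests only on these two values. A modest move toward a lower number is expected, a 1.8-fold lower number from compound 1 to compound 3 (0.26 log units; within the scatter). Compound 3 is estimated at 3800 nM, within a range from 1500 nM to 9500 nM.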

Compound 3, concentration for total growth inhibition: 31600 nM
Estimate against measurement, compound 3: 8.3-fold (0.92 log units) below; the whole stated range lies below it.
By their numbers in this assay, from the lowest: compound 2; then compound 1; then compound 3.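

Within the data shown here, compound 1 and compound 3 give the first reading of a single change on this aromatic carbon, between two ring nitrogen atoms. Chloro in place of hydrogen here gives a 4.6-fold higher number from compound 1 to compound 3 (0.66 log units; beyond the scatter) in this assay, so growth inhibition weakens. This position is therefore not indifferent to the change, at least in this pair. Nothing measured here explains the loss.

On these data alone, whether an amine or a methoxy group on the same carbon would also raise the number stays open. So does whether this chloro would have the same effect with the rest of compound 2 .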